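The compounds below may be only part of what the source reports. "The series", "measured", "known", "first", "only" and "open" are said of these compounds alone.

Measured so far:
compound 1 `O=C(O)c1ccc2noc(-c3ccc(Oc4ccccc4)cc3)c2c1` — 280 nM in an assay for inhibition of inositol hexakisphosphate kinase 2 (Homo sapiens), read by colorimetric assay, coupled enzyme assay and malachite green, with a stated time of 120 min, in the presence of a further agent that is not named here; on this read-out lower numbers stand for stronger inhibition and higher numbers for weaker inhibition
compound 2 `O=C(O)c1ccc2noc(-c3ccc(N4CCCC4=O)cc3)c2c1` — 480 nM

Among the measured compounds shown here, compound 2 gives the larger of the two numbers, but the single step, a 1.7-fold higher number from compound 1 to compound 2 (0.23 log units; within the scatter), lies within the scatter, so the two are not separated. Compound 3 `O=C(O)c1ccc2noc(-c3ccc(NC(=O)c4ccncn4)cc3)c2c1` differs from compound 2 by ((pyrimidin-4-yl)carbonyl)amino in place of 2-oxopyrrolidin-1-yl on an aromatic carbon. For the measured compounds named here, the only measured step that bears on this change is the one from compound 1 to compound 2, and it stayed within the scatter; no step beyond the scatter is expected in this assay, with an expected step of a 1.1-fold lower number from compound 2 to compound 3 (0.03 log units; within the scatter). Compound 3 is therefore estimated at 450 nM, with a range of 150 nM to 1500 nM.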

Compound 3, half-maximal inhibitory concentration: 720 nM
For compound 3 the middle estimate is 1.6-fold (0.20 log units) below the measured one; low and high end bracket the measured number.
By their numbers in this assay, from the lowest: compounds 1, 2 and 3 (each within the scatter of the next, the first and the last beyond it).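

In this assay, among the compounds shown here, the ((pyrimidin-4-yl)carbonyl)amino group gives the first step beyond the scatter (a 2.6-fold higher number from compound 1 to compound 3 (0.41 log units; beyond the scatter)), a modest loss against phenoxy, while against 2-oxopyrrolidin-1-yl the change remains unresolved (a 1.5-fold higher number from compound 2 to compound 3 (0.18 log units; within the scatter)). This position therefore tolerates a group with a hydrogen-bond donor, though here without any gain over phenoxy. No available evidence accounts for the step.

Open, on these data alone, is whether morpholin-4-yl or a plain acetylamino group here would match compound 1 or surpass it, and whether the pyrimidine ring or its amide link carries the step.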